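A few compounds are considered here, and "the series" means these few. Any claim that something is new, unique, unknown or untested is made for them only; others in the source may bear on it.

In a functional assay on A-375 cells (Homo sapiens) for activation, with a stated time of 3 days (on this read-out lower numbers stand for an effect already at smaller amounts and higher numbers for an effect only at larger amounts of compound), two compounds have been measured so far. Compound 1 `O=C(Nc1ccc(-c2cscn2)cc1)[C@H]1CCCN(Cc2ccc(F)c(F)c2)C1` gives 270 nM, and compound 2 `O=C(Nc1ccc(-c2cccnc2)cc1)C1CCCN(Cc2ccc(F)c(F)c2)C1` gives 1060 nM, the higher of the two numbers; its gap to compound 1 lies beyond the usual scatter. Compound 3 `O=C(Nc1ccc(-c2ccoc2)cc1)C1CCCN(Cc2ccc(F)c(F)c2)C1` has not yet been measured. It differs from compound 2 in one place: furan-3-yl in place of pyridin-3-yl on an aromatic carbon. Compound 1, which likewise carries a five-membered aromatic ring at this place, gave 270 nM, so a lower number than that of compound 2 is expected for compound 3, although the step may stay within the scatter. The expected step is a 1.8-fold lower number from compound 2 to compound 3 (0.25 log units; within the scatter). Compound 3 is estimated at 600 nM, within a range from 200 nM to 1800 nM.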

Compound 3, half-maximal effective concentration: 3000 nM
Beside the measured number, compound 3's estimate is 5.0-fold (0.70 log units) below it, outside the stated range (above it).
By their numbers in this assay, from the lowest: compound 1; then compound 2; then compound 3.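

In this assay, furan-3-yl in place of pyridin-3-yl on this aromatic carbon gives a 2.8-fold higher number from compound 2 to compound 3 (0.45 log units; beyond the scatter) and so shows that the number here responds to the choice of ring. A five-membered aromatic ring with one hetero atom is thus not enough in itself to bring a lower number at this place, and the two rings have the same counts of hydrogen-bond donors and acceptors. Nothing available here accounts for this step. Still open, going by these compounds, is how a non-ring group at this place, such as an amine or a carboxylic acid, would read in this assay.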